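The source may hold more compounds than are shown below. What is called first, only, known or untested is meant among the compounds shown, and "the series" means these compounds.

Measured compounds:
Compound 1, `CCCCCCCCC(C)Nc1ccc(NC(=O)c2cc(Cl)ccc2O)c(Cl)c1`: in an ADME assay on A549 cells (Homo sapiens) for cytotoxicity, read by resazurin assay, with a stated time of 48 h (a higher number here means that more compound is tolerated, a lower number that less compound is tolerated), compound 1 gives 21900 nM
Compound 2, `CCCN(CCC)c1ccc(NC(=O)c2cc(Cl)ccc2O)c(Cl)c1`: in this assay compound 2 gives 10700 nM
Compound 3, `CC1(ON(c2ccc(NC(=O)c3cc(Cl)ccc3O)c(Cl)c2)C2(C)CCCC2)CCCC1`: in this assay compound 3 gives 18000 nM

Among the three measured compounds, compound 2 carries the lowest number in this assay. Its gap to compound 3 lies within the scatter of the method, so the two cannot be ranked against each other; its gap to compound 1 lies just beyond the scatter, so compound 1 is tolerated at a somewhat higher concentration than compound 2. All three numbers sit in a fairly narrow band.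

The step considered here leads from compound 2 to the unmeasured compound 4, `O=C(Nc1ccc(NCc2cccc(Br)n2)cc1Cl)c1cc(Cl)ccc1O`. The shared core is kept, and the change is confined to one substituent: ((6-bromopyridin-2-yl)methyl)amino in place of dipropylamino on an aromatic carbon.

Among the measured compounds shown here, no measured pair in this set differs in a single place, so there is no directly comparable step to lean on. Given how closely the three measured values cluster in this assay, the expected step of a 1.1-fold higher number from compound 2 to compound 4 (0.05 log units; within the scatter) is small and, in the estimate, does not go beyond the scatter in either direction. Compound 4 is therefore estimated at 12000 nM in this assay, with a likely range from 4000 nM to 35000 nM.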

Compound 4, half-maximal cytotoxic concentration: 92300 nM
For compound 4 the middle estimate is 7.7-fold (0.89 log units) below the measured one, and the stated range ends below it.
By their numbers in this assay, from the lowest: compounds 2, 3 and 1 (each within the scatter of the next, the first and the last beyond it); then compound 4.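

In this assay, putting ((6-bromopyridin-2-yl)methyl)amino in place of dipropylamino gives an 8.6-fold higher number from compound 2 to compound 4 (0.94 log units; beyond the scatter), so a change of substituent at this aromatic carbon, meta to a chloro group, can shift the number beyond the scatter, towards more compound being tolerated. The earlier compounds offered no step in a single place and could not show this; here one substituent alone accounts for the difference between the two structures, as the entering group brings a six-membered aromatic ring with one hetero atom, a bromine and a hydrogen-bond donor. Nothing available indicates why the number moves or which of these features is responsible.

The compounds shown leave open whether the step follows the bromine, the ring or the amine hydrogen: a (pyridin-2-yl)methylamino group without the bromine, a benzylamino group with a ring of carbon only, or a simple propylamino group would each separate one of these from the others. Going by these compounds, it also remains open whether the same exchange would give a step of similar size on a different core.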